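This account rests on a few compounds, and the source may have more. Where it says the series, first, only, none or still open, it means among the compounds named here.

Measured in a functional assay on PC-3 cells (Homo sapiens) for antiproliferative activity, read by MTT assay, with a stated time of 48 h; on this read-out lower numbers stand for stronger inhibition and higher numbers for weaker inhibition:
Compound 1 `CC1(C)Cc2c(ccc(C(=O)/C=C/c3cn(-c4ccccc4)nc3-c3ccccc3)c2OCc2ccccc2)O1`, reported only as a limit: > 100000 nM.
Compound 2 `CC1(C)Cc2c(OCc3ccccc3)ccc(C(=O)/C=C/c3cn(-c4ccccc4)nc3-c3ccc([N+](=O)[O-])cc3)c2O1`, reported only as a limit: > 100000 nM.
Compound 3 `CC1(C)Cc2c(OCc3ccccc3)ccc(C(=O)/C=C/c3ccc(Br)cc3)c2O1`, reported only as a limit: > 100000 nM.

Compound 1 therefore stands at the assay limit, as described by the limit of > 100000 nM in this assay, at which 3 of the 3 values shown sit, and no ordering among the three measured compounds can be drawn. Compound 4 `CC1(C)Cc2c(ccc(C(=O)/C=C/c3cn(-c4ccccc4)nc3-c3ccc(Cl)cc3)c2OCc2ccccc2)O1` differs from compound 1 by chloro in place of hydrogen on an aromatic carbon. Among the measured compounds shown here, no step between measured compounds is available, so the size of this change in this assay cannot be read from any measured pair. For the measured compounds named here, compound 2 also sits only at the limit, and nothing among the measured compounds points to a move beyond the scatter. Compound 4 is thus expected at 150000 nM (range 50000 nM to 500000 nM), a step that the limit leaves unreadable from compound 1 to compound 4 that is expected to remain within the scatter, most likely reported again as a limit.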

Compound 4, half-maximal inhibitory concentration: 26000 nM
Beside the measured number, compound 4's estimate is 5.8-fold (0.76 log units) above it; measured number below the stated range.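

In this assay, among the compounds shown here, the change from phenyl to 4-chlorophenyl gives an at least 3.8-fold lower number from compound 1 to compound 4 (0.58 log units; beyond the scatter), so a substituent at this position can move the read-out, which the earlier compounds could not show. The step is only a bound, since compound 1 is reported as a limit. Compound 4 is the one compound shown with a number rather than a limit: the limit of > 100000 nM in this assay, at which 3 of the 4 values shown sit.

On these data alone, how far the true step extends remains unknown. As far as these compounds go, whether fluoro, methoxy or an amine at this same place would have a similar effect also remains open.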